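Tetrazole replacements on a leukotriene receptor series

This account rests on a few compounds, and the source may have more. Where it says the series, first, only, none or still open, it means among the compounds named here.

Measured compounds:
compound 1 `CCc1cc(C(C)=O)c(O)cc1OCCCCCC(C)(C)C(=O)O`: 104%
compound 2 `CCc1cc(C(C)=O)c(O)cc1OCCCCCC(C)(C)c1nnn(C)n1`: 95%
compound 3 `CCc1cc(C(C)=O)c(O)cc1OCCCCCCC(=O)Nc1nn[nH]n1`: 101%

In an assay on isolated protein for inhibition of leukotriene B4 receptor 1 (Homo sapiens), tested at 10 uM (on this read-out lower numbers stand for less inhibition and higher numbers for more inhibition at the one concentration tested (going by the name of the read-out)), compound 1 gives the largest of the three numbers, but its gaps to the other two both lie within the scatter: a number 3 percentage points lower from compound 1 to compound 3 (within the scatter) and a number 9 percentage points lower from compound 1 to compound 2 (within the scatter). The pair of compounds 2 and 3 also sit within the scatter of each other, a number 6 percentage points higher from compound 2 to compound 3 (within the scatter).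

Compound 4 `CCc1cc(C(C)=O)c(O)cc1OCCCCc1nnn[nH]1` has not yet been measured in this assay. It differs from compound 1 as follows: 1H-tetrazol-5-yl in place of 2-carboxy-2-methylpropyl on a saturated chain carbon, four bonds along the chain from an oxygen on an aromatic ring. The group that leaves is 2-carboxy-2-methylpropyl, the group that enters is 1H-tetrazol-5-yl, on a saturated chain carbon four bonds along the chain from an oxygen on an aromatic ring.

Among the compounds with values here, the steps that bear on this change are those from compound 1 to compound 2, where a tetrazole stands in place of the carboxy group, and from compound 1 to compound 3, where a tetrazole-bearing group replaces the acid-bearing chain end; both remained within the scatter. No step beyond the scatter is therefore expected in this assay for compound 4: the expected step is a number 8 percentage points lower from compound 1 to compound 4 (within the scatter), and compound 4 is estimated at 96%, with a range from 82% to 108%.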

Compound 4, a percentage reported as inhibition, at one concentration (the size of the read-out at that concentration, not a potency): 49%
Compound 4: the middle estimate sits 47 percentage points above what was measured; measured number outside the range, below it.
By their numbers in this assay, from the lowest: compound 4; then compounds 2, 3 and 1 (each within the scatter of the next).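

In this assay, within the data shown here, the change at the saturated chain carbon four bonds along the chain from an oxygen on an aromatic ring gives a number 55 percentage points lower from compound 1 to compound 4 (beyond the scatter), the first step beyond the scatter. A tetrazole as such does not account for this: compounds 2 and 3 also carry one and stay within the scatter of compound 1, whereas in compound 4 the 1H-tetrazol-5-yl sits directly on this carbon and the 2-carboxy-2-methylpropyl end is gone. Nothing available explains the loss of inhibition.

The compounds shown leave open whether the drop follows the ring or the shorter reach of the chain end. A carboxylic acid on the same short chain, or a 1H-tetrazol-5-yl at the end of the longer chain with its two methyl groups, would separate the two.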